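The source may hold more compounds than are shown below. What is called first, only, known or untested is meant among the compounds shown, and "the series" means these compounds.

Measured so far in an in vitro functional assay on cells for antagonist activity at metabotropic glutamate receptor 1 (Rattus norvegicus), read by inositol phosphate accumulation; on this read-out lower numbers stand for stronger inhibition and higher numbers for weaker inhibition:
Compound 1 `CC1(C)CC(=O)c2ccc(NCc3ccccc3)nc2C1` gives 45000 nM.
Compound 2 `CC1(C)CC(=O)c2cc(C#N)c(NCc3ccccc3)nc2C1` gives 2500 nM.
Compound 3 `CN(Cc1ccccc1)c1nc2c(cc1C#N)C(=O)CC(C)(C)C2` gives 5300 nM.

Compound 2 has the lowest number of the three, so it is the strongest inhibitor in this set. Two steps lead to or from it. Adding a nitrile to the core gave an 18-fold lower number from compound 1 to compound 2 (1.26 log units; beyond the scatter), a large change. Putting a methyl on the nitrogen on the aromatic ring gave a 2.1-fold higher number from compound 2 to compound 3 (0.33 log units; beyond the scatter), a modest change in the other direction.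

Compound 4 `CCCNc1nc2c(cc1C#N)C(=O)CC(C)(C)C2` differs from compound 2 at a different place: ethyl in place of phenyl on a saturated chain carbon bound to a nitrogen on an aromatic ring. The arm hanging from the nitrogen on the aromatic ring loses its aromatic ring and becomes a short plain chain. Neither measured step touches this arm; one alters an aromatic carbon of the core, the other the nitrogen itself. The measured data therefore offer no direct guide to this change, and any expectation is loosely held.

With that caution, compound 4 is expected to give a higher number than compound 2, a step of a 6.0-fold higher number from compound 2 to compound 4 (0.78 log units; beyond the scatter). Compound 4 is estimated at 15000 nM in this assay, with a wide range from 3000 nM to 70000 nM.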

Compound 4, half-maximal inhibitory concentration: 2300 nM
Compound 4: middle estimate off by 6.5-fold (0.81 log units), on the high side; the measured number lies below the stated range.
By their numbers in this assay, from the lowest: compounds 4 and 2 (each within the scatter of the next); then compound 3; then compound 1.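

Replacing phenyl with ethyl on a saturated chain carbon bound to a nitrogen on an aromatic ring gives, in this assay, a 1.1-fold lower number from compound 2 to compound 4 (0.04 log units; within the scatter), so this pair of compounds cannot be told apart on this read-out. Among the compounds shown here, this is the first view of the arm itself, as the earlier steps altered only an aromatic carbon of the core and the nitrogen: with the nitrile in place, a benzyl arm, with its six-membered aromatic ring of carbon, and a propyl arm, with no ring, read alike here, which shows that in this pair the aromatic ring is not required for a number at this level. Nothing shown explains why these two arms read alike.

The compounds shown leave open how far this tolerance extends, for instance whether a longer chain such as hexyl, a cyclohexylmethyl arm, or a chain ending in an amine or a carboxylic acid would also read alike. They also leave open whether the cyano and methyl steps, seen so far only with the benzyl arm, would have the same size with the propyl arm.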